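The compounds below may be only part of what the source reports. "The series", "measured", "known", "first", "only" and "open" are said of these compounds alone.

Measured so far:
- compound 1, `CC(C)(C)c1ccc(Nc2nc3nonc3nc2O)cc1`: 3900 nM
- compound 2, `CC(=O)c1ccc(Nc2nc3nonc3nc2O)cc1`: 93700 nM

Both numbers come from an assay on mitochondria from L6 cells (Rattus norvegicus) for activation, with a stated time of 90 min; a lower number here means that less compound is needed, a higher number that more compound is needed for the effect. Among the measured compounds shown here, compound 2 stands at the higher of the two numbers, meaning more of it is needed than of compound 1; the single measured step, a 24-fold higher number from compound 1 to compound 2 (1.38 log units; beyond the scatter), is large and well beyond the scatter.

Compound 3, `Oc1nc2nonc2nc1Nc1ccc(OC(F)F)cc1`, has not been measured. It differs from compound 2 in one place: difluoromethoxy in place of acetyl on an aromatic carbon. The group enters on an aromatic carbon of a six-membered aromatic ring of carbon only, the same place where the acetyl of compound 2 sits.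

For the measured compounds named here, only one step bears on this change, and it compares acetyl with tert-butyl, not with difluoromethoxy. That step shows that swapping the group at this position can move this assay by a large amount. Difluoromethoxy is a third, different group, so the direction is uncertain, but since compound 2 holds the highest number seen, a drop toward compound 1 seems the more likely outcome. The expected step is therefore a 6.2-fold lower number from compound 2 to compound 3 (0.80 log units; beyond the scatter). For compound 3 the estimate is 15000 nM, within a range from 3000 nM to 70000 nM.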

Compound 3, half-maximal effective concentration: 20600 nM
Compound 3: middle estimate off by 1.4-fold (0.14 log units), on the low side; low and high end bracket the measured number.
By their numbers in this assay, from the lowest: compound 1; then compound 3; then compound 2.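

In this assay, the new step, a 4.5-fold lower number from compound 2 to compound 3 (0.66 log units; beyond the scatter), shows that the high number of compound 2 is not shared by every replacement of acetyl at this place on the six-membered ring: a second, quite different group also brings the number down. The other step, a 5.3-fold higher number from compound 1 to compound 3 (0.72 log units; beyond the scatter), shows that this drop stops short of tert-butyl, so difluoromethoxy sits between the two earlier groups and the three groups give three clearly separate numbers at this one position. Acetyl and difluoromethoxy are alike in their counts of hydrogen-bond donors and acceptors, so those counts do not separate them, and nothing available here accounts for the order of the three groups.

Three groups are too few to show whether this order follows a general rule, and an amine, a carboxylic acid or a longer chain such as n-butyl could fall anywhere relative to them. From the compounds shown here alone, it also remains open whether the same order would hold with these groups at another place on the ring, or with changes elsewhere on the shared core.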